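A Second Chloro Enters the Core of Compound 1

The source may report more compounds than this note shows. Statements on the series, on what has been measured and on what is new or still open speak of the compounds shown alone.

Compound 1 `ClCc1ccc(Cn2cnc3c(Cl)ncnc32)cc1` is the point of departure. In a functional assay on COLO 205 cells (Homo sapiens) for cytotoxicity, read by sulforhodamine B assay, with a stated time of 48 h (a higher number here means that more compound is tolerated, a lower number that less compound is tolerated), compound 1 gives > 100000 nM, which is a limit of the assay and not a number. Compound 2 `ClCc1cccc(Cn2cnc3nc(Cl)nc(Cl)c32)c1` belongs to the same set, but in this assay compound 2 gives "not determined" (no result reported). So compound 1 stands at the limit of > 100000 nM in this assay, at which 1 of the 2 values shown sits, and the other entry adds no number to compare with.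

Compound 3 `ClCc1ccc(Cn2cnc3c(Cl)nc(Cl)nc32)cc1` has not yet been tested. It differs from compound 1 by chloro in place of hydrogen on an aromatic carbon. Going by the values given here, no step between two measured compounds is known here, so nothing shows how such a change has moved the read-out before. Given that compound 1 already rests at a limit, no step beyond the usual scatter is expected in this assay, in either direction. Compound 3 is therefore estimated at 100000 nM, within 30000 nM to 300000 nM, a step of a number no higher from compound 1 to compound 3 (the limit leaves the size open) that is expected to be flat.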

Compound 3, concentration lethal to 50% of the cells: > 100000 nM
Compound 3: only a limit was reported; the forecaster's own chance of this, stated with the estimate: 75%; the middle value lies on the limit itself.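

In this assay compound 3 gives > 100000 nM, which is a limit of the assay and not a number. No step can be read between compound 1 and compound 3, which both stand at a limit: the limit of > 100000 nM in this assay, at which 2 of the 3 values shown sit.

Going by these compounds, whether chloro in place of hydrogen on an aromatic carbon moves the read-out at all stays open.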